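The source may hold more compounds than are shown below. What is called first, only, known or untested is meant among the compounds shown, and "the series" means these compounds.

Compound 2 `O=S(=O)(Oc1cccc2cccnc12)c1ccccc1`: 49500 nM
Compound 1 `O=[N+]([O-])c1ccc(S(=O)(=O)Nc2cnc3ccccc3c2)cc1`: 31600 nM

Both compounds were tested in an assay for inhibition of beta-glucuronidase (Bos taurus), read by spectrophotometry, with a stated time of 30 min; on this read-out lower numbers stand for stronger inhibition and higher numbers for weaker inhibition. Compound 2 gives 49500 nM in this assay, the higher of the two numbers, and compound 1 gives 31600 nM; the two values lie within the usual scatter of one another, so neither compound can be called the stronger inhibitor on this evidence. Going by the values given here, no pair of measured compounds differs in a single place, so no measured step is available as a guide.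

Compound 3 `O=[N+]([O-])c1cccc(S(=O)(=O)Oc2cccc3cccnc23)c1` has not yet been measured. It differs from compound 2 by nitro in place of hydrogen on an aromatic carbon. Among the compounds with values here, with no measured step of this kind at hand, the expectation in this assay is a change no larger than the scatter, if anything toward a somewhat lower number. The step of a 1.4-fold lower number from compound 2 to compound 3 (0.15 log units; within the scatter) is what the estimate amounts to. Compound 3 is therefore expected to give about 35000 nM, within a range from 12000 nM to 100000 nM.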

Compound 3, half-maximal inhibitory concentration: 30100 nM
Compound 3: the middle estimate sits 1.2-fold (0.07 log units) above what was measured; low and high end bracket the measured number.
By their numbers in this assay, from the lowest: compounds 3, 1 and 2 (each within the scatter of the next).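

Going by these compounds alone, compound 3 provides the first measured step between two compounds that differ in only one place. In this assay, nitro in place of hydrogen on an aromatic carbon, meta to a large group, gives (a 1.6-fold lower number from compound 2 to compound 3 (0.22 log units; within the scatter)) . At this position, then, adding the three heavy atoms of nitro to the six-membered aromatic ring of carbon only leaves the read-out within the scatter, so this single step reveals no measurable effect on inhibition, and no available measurement bears on why that is so. On these data alone, whether an amine or a carboxylic acid in this same place would move the number beyond the scatter remains open. Also open, as far as these compounds go, is whether nitro at another position on this ring would give a different result.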